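One Carbon Longer: From Compound 2 to Compound 4

The source may hold more compounds than are shown below. What is called first, only, known or untested is meant among the compounds shown, and "the series" means these compounds.

Of the compounds shown here, three have so far been tested in a functional assay on MCF7 cells (Homo sapiens) for cytotoxicity, read by MTT assay, with a stated time of 72 h; on this read-out lower numbers stand for higher toxicity in this test and higher numbers for lower toxicity in this test. Compound 1 `N#C[Se]c1ccc(NC(=O)Oc2ccc(F)cc2)cc1` gives 65700 nM, compound 2 `CCCOC(=O)Nc1ccc([Se]C#N)cc1` gives 67500 nM and compound 3 `Cc1ccc(OC(=O)Nc2ccc([Se][Se]c3ccc(NC(=O)Oc4ccc(C)cc4)cc3)cc2)cc1` gives 74000 nM. Compound 2 holds the second highest of these three numbers, yet both neighbours sit close to it: compound 1 lies within the scatter of repeated measurement, and so does compound 3. In practice the three results cannot be told apart.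

Compound 4 `CCCCOC(=O)Nc1ccc([Se]C#N)cc1` has not yet been measured. It differs from compound 2 by methyl in place of hydrogen on a saturated chain carbon, three bonds along the chain from an oxygen next to a carbonyl group; cut one bond further out, the same change reads propyl to butyl. Among the measured compounds shown here, no measured pair among the three shows what such a change does in this assay, so there is no earlier step to lean on. Since the three measured numbers sit so closely together, the step from compound 2 to compound 4 is expected to stay within the scatter, a 1.1-fold lower number from compound 2 to compound 4 (0.04 log units; within the scatter), with no clear direction. Compound 4 is therefore estimated at 62000 nM, with a range from 30000 nM to 125000 nM.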

Compound 4, concentration lethal to 50% of the cells: 59700 nM
The estimate for compound 4 lay 1.0-fold (0.02 log units) above the measured number; measured number inside the range.
By their numbers in this assay, from the lowest: compounds 4, 1, 2 and 3 (each within the scatter of the next).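

In this assay, among the compounds shown here, this pair gives the first reading of a single change: propyl to butyl, that is, methyl in place of hydrogen on a saturated chain carbon, three bonds along the chain from an oxygen next to a carbonyl group, amounts to a 1.1-fold lower number from compound 2 to compound 4 (0.05 log units; within the scatter). For the compounds shown here, at this position, then, one more chain carbon gives two numbers that cannot be told apart in this test, something the earlier compounds, with no single-change pair among them, could not show. Nothing at hand offers a reason for this result.

On these data alone, whether a longer chain such as octyl, or a chain ending in an amine or a carboxylic acid, would give a step beyond the scatter stays open. One step also shows no trend along the chain.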